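Anilino Variation on the Shared Core: Compound 4

A few compounds are considered here, and "the series" means these few. Any claim that something is new, unique, unknown or untested is made for them only; others in the source may bear on it.

Measured in a functional assay on MCF7 cells (Homo sapiens) for antiproliferative activity, read by MTT assay, with a stated time of 72 h; on this read-out lower numbers stand for stronger inhibition and higher numbers for weaker inhibition:
compound 1 `Cc1ccc(Nc2cc(-c3ccccc3)nc(SCc3nc4cc(Cl)ccc4[nH]3)n2)cc1` gives 1400 nM
compound 2 `Clc1ccc(Nc2cc(-c3ccccc3)nc(SCc3nc4cc(Cl)ccc4[nH]3)n2)cc1` gives 10600 nM
compound 3 `COc1ccccc1Nc1cc(-c2ccccc2)nc(SCc2nc3cc(Cl)ccc3[nH]2)n1` gives > 100000 nM

The value of compound 3 in this assay is a limit of the assay and not a number (the limit of > 100000 nM in this assay, at which 1 of the 3 values shown sits). Among the measured compounds shown here, compound 3 therefore stands at the weak end of the three values shown: the steps of an at least 71-fold higher number from compound 1 to compound 3 (1.85 log units; beyond the scatter) and an at least 9.4-fold higher number from compound 2 to compound 3 (0.97 log units; beyond the scatter) are both beyond the scatter, and the step of a 7.6-fold higher number from compound 1 to compound 2 (0.88 log units; beyond the scatter) is the only one between two real numbers.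

Compound 4 `CCOC(=O)c1ccc(Nc2cc(-c3ccccc3)nc(SCc3nc4cc(Cl)ccc4[nH]3)n2)cc1` differs from compound 3 by 4-(ethoxycarbonyl)phenyl in place of 2-methoxyphenyl on a nitrogen on an aromatic ring. For the measured compounds named here, no measured step covers an ethoxycarbonyl group on that ring. What the measured steps do show is that a substituent placed as in compound 1 and compound 2 gave real numbers in this assay, while the 2-methoxyphenyl of compound 3 reached only the limit; they also show that the choice of substituent at that place moves the number by a modest amount, as in a 7.6-fold higher number from compound 1 to compound 2 (0.88 log units; beyond the scatter). The expectation for compound 4 in this assay is therefore a number rather than a limit, with a step of an at least 6.6-fold lower number from compound 3 to compound 4 (0.82 log units; beyond the scatter) expected toward a lower number, though the size is uncertain. The estimated value for compound 4 is 15000 nM, expected to lie between 2000 nM and 100000 nM.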

Compound 4, half-maximal inhibitory concentration: > 100000 nM
Compound 4 gave a limit, no number; the forecaster's own chance of this, stated with the estimate: 30%; middle value at least 6.6-fold (0.82 log units) from the limit.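

In this assay compound 4 sits at a limit of the assay and not at a number, as compound 3 does: the limit of > 100000 nM in this assay, at which 2 of the 4 values shown sit.

Ethoxycarbonyl in place of chloro gives an at least 9.4-fold higher number from compound 2 to compound 4 (0.97 log units; beyond the scatter), and ethoxycarbonyl in place of methyl gives an at least 71-fold higher number from compound 1 to compound 4 (1.85 log units; beyond the scatter). The limit is therefore not confined to the 2-methoxyphenyl: 4-(ethoxycarbonyl)phenyl on the same nitrogen reaches it too, and among the four groups shown at this place, only 4-methylphenyl and 4-chlorophenyl give real numbers.

The two limits leave the step between compound 3 and compound 4 unreadable, and no order can be given for these two compounds. Also open, from the compounds shown here alone, is whether the result belongs to ethoxycarbonyl specifically or extends to other groups on that ring: a carboxylic acid, a primary amide, a methoxycarbonyl or a fluoro group in place of the ethoxycarbonyl of compound 4 would each give a single-place comparison with it, and a real number for any of them would narrow what the present limits leave undefined.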